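This account rests on a few compounds, and the source may have more. Where it says the series, first, only, none or still open, it means among the compounds named here.

Measured compounds and their values in a functional assay on CHO cells for agonist activity at Free fatty acid receptor 1 (Homo sapiens); on this read-out higher numbers stand for an effect only at larger amounts of compound and lower numbers for an effect already at smaller amounts:

compound 1 `O=C(O)/C=C/c1ccc(NCc2cccc(Oc3ccccc3)c2)cc1` gives 145 nM
compound 2 `Cc1nc(-c2ccc(C(F)(F)F)cc2)sc1CNc1ccc(/C=C/C(=O)O)cc1` gives 36.3 nM
compound 3 `O=C(O)COc1ccc(NCc2cccc(Oc3ccccc3)c2)cc1` gives 2040 nM

Compound 2 has the lowest of the three numbers in this assay, and its steps to compound 1 and to compound 3 both lie beyond the scatter. The difference between the core of compound 1 and the core of compound 2 is not broken down here.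

One structural change appears twice in the set. From compound 1 to compound 3 it is carboxymethoxy in place of 2-carboxyethenyl on an aromatic carbon, and the measured step that goes with it is a 14-fold higher number from compound 1 to compound 3 (1.15 log units; beyond the scatter). The unmeasured compound 4 `Cc1nc(-c2ccc(C(F)(F)F)cc2)sc1CNc1ccc(OCC(=O)O)cc1` is related to compound 2 by the same change, (carboxymethoxy in place of 2-carboxyethenyl on an aromatic carbon); the two place descriptions agree word for word, so this is the same change made on a different core.

Going by the values given here, only one measured example of the change exists, so the expectation for compound 4 rests on the single pair compound 1 and compound 3. Among the compounds with values here, compound 4 is expected to show a step of a 14-fold higher number from compound 2 to compound 4 (1.14 log units; beyond the scatter) in this assay, set beside the earlier step, because a 14-fold higher number from compound 1 to compound 3 (1.15 log units; beyond the scatter) is the only guide available and the change sits at the same kind of place on a core that, in compound 2, already gives 36.3 nM. Whether the core of compound 2 carries the change in the same way is not known from these data, so the range is kept wide. The estimate for compound 4 in this assay is 500 nM, with a range from 180 nM to 1400 nM.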

Compound 4, half-maximal effective concentration: 288 nM
The estimate for compound 4 lay 1.7-fold (0.24 log units) above the measured number, within the range that was stated.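

In this assay, carboxymethoxy in place of 2-carboxyethenyl on an aromatic carbon gives a 7.9-fold higher number from compound 2 to compound 4 (0.90 log units; beyond the scatter), so the number rises on the second core as it did on the first. The size of the step does not differ between the two cores: the same change on two cores in this assay, a 14-fold higher number (1.15 log units; beyond the scatter) from compound 1 to compound 3 and a 7.9-fold higher number (0.90 log units; beyond the scatter) from compound 2 to compound 4, 1.8-fold (0.25 log units) apart, within the scatter of two such steps. This shows that the change carries over between these two cores in this assay, but two pairs give no rule for other cores, and the numbers alone do not say why either step occurs.

The change replaces several features at once, since carboxymethoxy enters with one double bond fewer outside aromatic rings and one more hydrogen-bond acceptor, so the compounds shown do not separate the contribution of each, and a saturated 2-carboxyethyl group at the same place, para to a large group, would be the obvious case to separate them. Also open, going by these compounds, are a longer chain ending in a carboxylic acid and a tetrazole in place of the carboxylic acid, and whether any of these would follow the same trend on both cores.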